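Trading an aromatic ring for a butyl chain

The source may report more compounds than this note shows. Statements on the series, on what has been measured and on what is new or still open speak of the compounds shown alone.

In a functional assay on a cell-free system (plasma, Homo sapiens), with a stated time of 3 min (a higher number here means a weaker inhibitor, a lower number a stronger inhibitor), compound 2 `Cc1cccc([C@@H](O)C(=O)N2N=CC[C@H]2C(=O)NCc2cc(Cl)ccc2-n2cnnn2)c1` gives 830 nM. Compound 3 `O=C(NCc1cc(Cl)ccc1-n1cnnn1)[C@@H]1C[C@@H]2C[C@@H]2N1C(=O)[C@H](O)C1CCCCC1` gives 600 nM, which lies within the usual scatter of compound 2. Compound 1 `O=C(NCc1cc(Cl)ccc1-n1cnnn1)[C@@H]1C[C@@H]2C[C@@H]2N1C(=O)[C@H](O)CC1CC1` gives 1700 nM, a gap from compound 2 that lies just beyond that scatter.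

Compound 4 `CCCC[C@@H](O)C(=O)N1N=CC[C@H]1C(=O)NCc1cc(Cl)ccc1-n1cnnn1`, not yet measured, keeps the core of compound 2 and changes one group on a saturated chain carbon bound to a carbonyl carbon and an oxygen on a saturated carbon: butyl in place of 3-methylphenyl (butyl in place of 3-methylphenyl on a saturated chain carbon bound to a carbonyl carbon and an oxygen on a saturated carbon).

Going by the values given here, only one measured step bears on this change: a 2.8-fold lower number from compound 1 to compound 3 (0.45 log units; beyond the scatter). It swaps groups at the same kind of carbon, but on a different core, so it is only a loose guide. In that step the cyclohexyl of compound 3 goes with the lower number, and cyclopropylmethyl, the group closer to butyl, goes with the higher one. Among the compounds with values here, no measured pair replaces an aromatic ring with an open chain. A modest move toward a higher number, meaning a weaker inhibitor, therefore seems most likely. The expected step is a 2.3-fold higher number from compound 2 to compound 4 (0.36 log units; beyond the scatter). Compound 4 is estimated at 1900 nM, with an expected range of 700 nM to 5000 nM.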

Compound 4, half-maximal inhibitory concentration: 610 nM
Compound 4: the middle estimate sits 3.1-fold (0.49 log units) above what was measured; measured number outside the range, below it.
By their numbers in this assay, from the lowest: compounds 3, 4 and 2 (each within the scatter of the next); then compound 1.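

In this assay, the exchange gives a 1.4-fold lower number from compound 2 to compound 4 (0.13 log units; within the scatter), so on this core the two groups cannot be told apart, even though butyl has no ring and fewer heavy atoms than 3-methylphenyl. Going by these compounds alone, the aromatic ring at this saturated chain carbon is therefore not required to keep the number in this range, which the earlier compounds could not show, as none of them carried an open chain in place of an aromatic ring. Within the data shown here, the only earlier step at this kind of carbon, a 2.8-fold lower number from compound 1 to compound 3 (0.45 log units; beyond the scatter), lies on a different core and beyond the scatter, so a difference between groups there did not carry over to this pair, and no measurement at hand explains why the ring can be given up here.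

On these data alone, how far this freedom reaches stays open: a shorter chain such as ethyl, a longer one such as hexyl, or a butyl chain ending in an amine or a carboxylic acid could hold the number or shift it. Butyl also appears only on the core of compound 2, so how it would compare with cyclohexyl or cyclopropylmethyl on the core of compound 1 remains unknown.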